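Amide substituent series: propyl analogue of compound 3

This account rests on a few compounds, and the source may have more. Where it says the series, first, only, none or still open, it means among the compounds named here.

Measured compounds in an ADME assay on HEK293 cells (Homo sapiens) for antiproliferative activity, read by MTT assay; on this read-out lower numbers stand for stronger inhibition and higher numbers for weaker inhibition:
- compound 1 `CNC(=O)c1oc2nc(-c3cccs3)cc(C(F)(F)F)c2c1N`: 75000 nM
- compound 2 `CCNC(=O)c1oc2nc(-c3cccs3)cc(C(F)(F)F)c2c1N`: 62000 nM
- compound 3 `Nc1c(C(=O)NC2CCCC2)oc2nc(-c3cccs3)cc(C(F)(F)F)c12`: 51000 nM

All three share one core and differ only in the group on the amide nitrogen. The three numbers cannot be told apart: the step of a 1.2-fold lower number from compound 1 to compound 2 (0.08 log units; within the scatter) and the step of a 1.2-fold lower number from compound 2 to compound 3 (0.08 log units; within the scatter) are both within the scatter, as is the step of a 1.5-fold lower number from compound 1 to compound 3 (0.17 log units; within the scatter). Among the measured compounds shown here, compound 3 therefore stands at the small-number end of the three only nominally, with no step to any other compound beyond the scatter.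

Compound 4 `CCCNC(=O)c1oc2nc(-c3cccs3)cc(C(F)(F)F)c2c1N` is the next member, not yet measured. Its difference from compound 3 is propyl in place of cyclopentyl on an amide-type nitrogen. The measured steps that bear on this are the exchanges of hydrogen, methyl, ethyl and cyclopentyl on the same nitrogen, none of which moved the number beyond the scatter. A propyl group sits between ethyl and cyclopentyl in size, and on this evidence no step beyond the scatter is expected from compound 3 to compound 4 in this assay; the expected step is a 1.1-fold higher number from compound 3 to compound 4 (0.03 log units; within the scatter). The estimate for compound 4 is 55000 nM, with an expected range from 30000 nM to 100000 nM.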

Compound 4, half-maximal inhibitory concentration: 64000 nM
Beside the measured number, compound 4's estimate is 1.2-fold (0.07 log units) below it; the measured number falls inside the stated range.
By their numbers in this assay, from the lowest: compounds 3, 2, 4 and 1 (each within the scatter of the next).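

In this assay, the propyl group on the amide-type nitrogen leaves every comparison within the scatter: the steps read a 1.3-fold higher number from compound 3 to compound 4 (0.10 log units; within the scatter) and a 1.0-fold higher number from compound 2 to compound 4 (0.01 log units; within the scatter) and a 1.2-fold lower number from compound 1 to compound 4 (0.07 log units; within the scatter) and none separates compound 4 from an earlier compound. Across compounds 3 and 4, exchanging cyclopentyl for propyl removes the five-membered carbon ring and two carbon atoms without a step beyond the scatter, so the ring is not required to keep the number within the scatter of the open-chain compounds 2 and 4. Compounds 1, 2, 3 and 4 therefore show this position as flat in this assay across methyl, ethyl, propyl and cyclopentyl, and nothing available explains that flatness.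

From the compounds shown here alone, whether any group on this nitrogen can produce a step beyond the scatter remains open, for example a longer chain such as hexyl, a benzyl group, or a chain ending in an amine or a carboxylic acid. Also open, going by these compounds, is what exchanging the trifluoromethyl group, shared by all four compounds, would do to the number.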